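A few compounds are considered here, and "the series" means these few. Any claim that something is new, unique, unknown or untested is made for them only; others in the source may bear on it.

Measured so far in a functional assay on A549 cells (Homo sapiens) for inhibition, read by MTT assay, with a stated time of 24 h; on this read-out higher numbers stand for weaker inhibition and lower numbers for stronger inhibition:
compound 1 `CC1(C)[C@H]2CC[C@]1(C)N(Cc1cn(-c3ccccc3)nn1)C(=O)C2`: 70 nM
compound 2 `CC1(C)[C@H]2CC[C@]1(C)N(Cc1cn(-c3cccc(O)c3)nn1)C(=O)C2`: 180 nM

Compound 2 holds the higher of the two numbers and is therefore the weaker inhibitor of the pair. Next in line is compound 3 `CC1(C)[C@H]2CC[C@]1(C)N(Cc1cn(-c3cccc(Br)c3)nn1)C(=O)C2`, not yet measured. The change is bromo in place of hydroxy on an aromatic carbon, 3-hydroxyphenyl to 3-bromophenyl: bromo in place of hydroxy on an aromatic carbon. Among the compounds with values here, only one measured step bears on it, the modest 2.6-fold higher number from compound 1 to compound 2 (0.41 log units; beyond the scatter), where hydroxy came in place of hydrogen. Within the data shown here, no measured compound carries bromo, so that step gives only a partial guide. With the hydroxy gone, a modest move back toward the number of compound 1, 70 nM, is expected in this assay. The expected step is a 2.0-fold lower number from compound 2 to compound 3 (0.30 log units; within the scatter). For compound 3 the estimated value is 90 nM, with an expected range of 30 nM to 250 nM.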

Compound 3, half-maximal inhibitory concentration: 90 nM
Beside the measured number, compound 3's estimate shows no gap at the digits printed; the range from low to high includes it.
By their numbers in this assay, from the lowest: compounds 1, 3 and 2 (each within the scatter of the next, the first and the last beyond it).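

Working notes on the aromatic carbon that carried the hydroxy, in this assay: with bromo at this carbon, the comparison with the unsubstituted compound stays within the scatter (a 1.3-fold higher number from compound 1 to compound 3 (0.11 log units; within the scatter)). The exchange of hydroxy for bromo also stays within the scatter (a 2.0-fold lower number from compound 2 to compound 3 (0.30 log units; within the scatter)), so compound 3 cannot be separated from either neighbour, even though the two neighbours are separated from each other. The position therefore accepts bromo, which brings no hydrogen-bond donor or acceptor, but these numbers do not rank bromo against hydrogen or hydroxy, and nothing available explains them.

Open, as far as these compounds go, is how far this carbon tolerates groups of another kind, such as an amine, a carboxylic acid or a methoxy. Also open, from the compounds shown here alone, is whether bromo would read the same on another carbon of the aromatic ring.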